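Swapping the Side Chain of Compound 3 for Methylsulfanyl

This account rests on a few compounds, and the source may have more. Where it says the series, first, only, none or still open, it means among the compounds named here.

Compound 1 `O=C(CN(c1nc(Cl)nc2[nH]cnc12)C1CC1)NCC(=O)OCc1ccccc1`: 18.7%
Compound 2 `N=C(N)NCCC[C@H](NC(=O)CN(c1nc(Cl)nc2[nH]cnc12)C1CC1)C(=O)O`: 45.4%
Compound 3 `N=C(N)NCCC[C@H](NC(=O)CN(c1nc(Cl)nc2[nH]cnc12)C1CC1)C(=O)OCc1ccccc1`: 23.2%

In a functional assay on the whole organism (Tail, strain ICR) with Mus musculus as the target, in the tail flick test, with a stated time of 30 min, at a dose of 25 umol/kg by the oral route (on this read-out higher numbers stand for a stronger effect at the one dose given and lower numbers for a weaker effect), compound 1 gives 18.7%, compound 2 gives 45.4% and compound 3 gives 23.2%. Compound 3 thus stands second of the three numbers: it lies within the scatter of compound 1, since a number 4.5 percentage points higher from compound 1 to compound 3 (within the scatter), and it falls short of compound 2, since a number 22.2 percentage points lower from compound 2 to compound 3 (beyond the scatter).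

Compound 4 `CSCC[C@H](NC(=O)CN(c1nc(Cl)nc2[nH]cnc12)C1CC1)C(=O)OCc1ccccc1` differs from compound 3 in one place: a group of 2 heavy atoms (1 carbon, 1 sulfur; no ring) in place of a group of 5 heavy atoms (2 carbon, 3 nitrogen; no ring), on a saturated chain carbon, three bonds along the chain from an amide-type nitrogen and a carbonyl carbon. Among the compounds with values here, of the measured steps, only the one from compound 1 to compound 3 touches this chain carbon, and there a group of 7 heavy atoms in place of a hydrogen atom moved the read-out by a number 4.5 percentage points higher from compound 1 to compound 3 (within the scatter). The step from compound 2 to compound 3 concerns the ester oxygen and does not bear on this change. With the side chain on this carbon having made no difference beyond the scatter so far, compound 4 is expected to show no step beyond the scatter, a number 2.2 percentage points lower from compound 3 to compound 4 (within the scatter). Compound 4 is therefore estimated at 21%, in the range 8% to 34%.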

Compound 4, a percentage reported as activity, at one dose (the size of the read-out at that dose, not a potency): 22.2%
Compound 4: the middle estimate sits 1.2 percentage points below what was measured; low and high end bracket the measured number.
By their numbers in this assay, from the lowest: compounds 1, 4 and 3 (each within the scatter of the next); then compound 2.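

On the saturated chain carbon, three bonds along the chain from an amide-type nitrogen and a carbonyl carbon, methylsulfanyl with 0 hydrogen-bond donors in place of a group with 3 gives, in this assay, a number 1 percentage points lower from compound 3 to compound 4 (within the scatter). With the benzyl ester kept, 2-(methylsulfanyl)ethyl in place of hydrogen on the saturated chain carbon bound to an amide-type nitrogen and a carbonyl carbon gives a number 3.5 percentage points higher from compound 1 to compound 4 (within the scatter), so at this one dose this read-out separates neither of the two side chains from hydrogen or from each other. Nothing available here offers an explanation for this.

As far as these compounds go, it remains open whether a side chain ending in a carboxylic acid or a primary amine would behave likewise on this carbon. Also open, from the compounds shown here alone, is whether methylsulfanyl would give the same result with the free carboxylic acid of compound 2 in place of the benzyl ester.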